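Methyl on the fused ring of compound 2

This account rests on a few compounds, and the source may have more. Where it says the series, first, only, none or still open, it means among the compounds named here.

Compound 1: `COCOc1ccccc1-c1cc2cc(C)ccc2c(=O)[nH]1`, 160 nM
Compound 2: `COc1ccc(Cn2c(-c3ccccc3O)c(Br)c3ccccc3c2=O)cc1`, 31600 nM

In a functional assay on HL-60 cells (Homo sapiens) for cytotoxicity, read by sulforhodamine B assay (a higher number here means a weaker inhibitor, a lower number a stronger inhibitor), compound 1 gives 160 nM. Compound 2, in this assay, gives 31600 nM, the higher of the two measured values; the gap to compound 1 is far beyond the scatter, but the two compounds differ in several places at once, so the two numbers alone say nothing about any single change.

Compound 3 is `COc1ccc(Cn2c(-c3ccccc3O)c(Br)c3cc(C)ccc3c2=O)cc1`. It differs from compound 2 in one place: methyl in place of hydrogen on an aromatic carbon. Within the data shown here, no step between measured compounds isolates this change. Compound 1 also carries a methyl on its fused ring, yet it is built on a different core, so it cannot serve as a guide for the size of the step. With nothing to lean on, the methyl for hydrogen exchange is expected to move this assay little, likely no further than the scatter in either direction.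

Compound 3 is therefore estimated at 25000 nM, with a range of 7000 nM to 90000 nM, which means an expected step of a 1.3-fold lower number from compound 2 to compound 3 (0.10 log units; within the scatter).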

Compound 3, half-maximal inhibitory concentration: 24500 nM
For compound 3 the middle estimate is 1.0-fold (0.01 log units) above the measured one; the range from low to high includes it.
By their numbers in this assay, from the lowest: compound 1; then compounds 3 and 2 (each within the scatter of the next).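

In this assay, among these compounds, methyl in place of hydrogen gives the first comparison that isolates a single change, and it amounts to a 1.3-fold lower number from compound 2 to compound 3 (0.11 log units; within the scatter). At this place on the fused system, meta to a fused ring and para to a fused ring, the added carbon therefore leaves compound 2 and compound 3 indistinguishable in this read-out, so the methyl can be carried here without a measurable cost or gain in this assay. Nothing at hand bears on why this exchange has so little effect on the read-out.

The compounds shown leave open whether this place stays as indifferent to other groups, since a single methyl cannot say what an amine, a carboxylic acid or a longer chain would do here, whether that is a step beyond the scatter or none. They also leave open whether the same exchange would be as quiet on the core of compound 1, for which no comparison of a methyl against hydrogen stands among these compounds.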